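This account rests on a few compounds, and the source may have more. Where it says the series, first, only, none or still open, it means among the compounds named here.

Compound 2 `O=C(Nc1ccc(F)cc1)N1CCN(S(=O)(=O)c2sccc2-c2ccccc2Oc2ccc(O)c(O)c2)CC1` gives 33% in an assay for binding affinity to Apoptosis regulator Bcl-2 (Homo sapiens), read by fluorescence polarization, with stated times of 30 min and 20 min, tested at 100 uM (on this read-out higher numbers stand for more inhibition at the one concentration tested (going by the name of the read-out) and lower numbers for less inhibition), the higher of the two numbers shown, though only narrowly: compound 1 `O=C(Nc1cccc([N+](=O)[O-])c1)N1CCN(S(=O)(=O)c2sccc2-c2ccccc2Oc2ccc(O)c(O)c2)CC1` gives 30%, and the step between the two is a number 3 percentage points higher from compound 1 to compound 2 (within the scatter). Compound 3 `COc1ccc(Oc2ccccc2-c2ccsc2S(=O)(=O)N2CCN(C(=O)Nc3ccc(F)cc3)CC2)cc1OC` is not yet measured; it differs from compound 2 by 3,4-dimethoxyphenyl in place of 3,4-dihydroxyphenyl on an oxygen on an aromatic ring. Among the measured compounds shown here, the single measured step concerns the group on the amide-type nitrogen, not the group on an oxygen on an aromatic ring, so no measured step bears on this change. With no guide, the expected step of a number 6 percentage points lower from compound 2 to compound 3 (within the scatter) is none beyond the scatter. Compound 3 is estimated at 27%, between 5% and 50%.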

Compound 3, a percentage reported as inhibition, at one concentration (the size of the read-out at that concentration, not a potency): 15%
The estimate for compound 3 lay 12 percentage points above the measured number, and the stated range covers the measured number.
By their numbers in this assay, from the lowest: compound 3; then compounds 1 and 2 (each within the scatter of the next).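

In this assay, 3,4-dimethoxyphenyl in place of 3,4-dihydroxyphenyl gives a number 18 percentage points lower from compound 2 to compound 3 (beyond the scatter), so this position, unlike the group on the amide-type nitrogen, moves the read-out beyond the scatter. The entering group has 0 hydrogen-bond donors against 2 for the leaving group, and 10 heavy atoms against 8; this one step cannot separate those differences.

Open, going by these compounds, is whether a phenyl carrying one hydroxy and one methoxy group, or an amine or carboxylic acid in place of the hydroxy groups, would stand nearer compound 2. No measurement here accounts for the step.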